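Removing a methoxy group from the trimethoxy chalcone analogue

The source may report more compounds than this note shows. Statements on the series, on what has been measured and on what is new or still open speak of the compounds shown alone.

Compound 3 `COc1cc(OC)c(C(=O)/C=C/c2cn(-c3ccccc3)nc2-c2cccnc2)c(OC)c1`: 500 nM
Compound 2 `O=C(/C=C/c1cn(-c2ccccc2)nc1-c1cccnc1)c1cc[nH]c1`: 3300 nM
Compound 1 `O=C(/C=C/c1cn(-c2ccccc2)nc1-c1cccnc1)c1ccccn1`: 6400 nM

In a functional assay on Huh-7 cells (Homo sapiens) for inhibition, read by sulforhodamine B assay, with a stated time of 72 h (on this read-out lower numbers stand for stronger inhibition and higher numbers for weaker inhibition), compound 3 gives the lowest number of the three measured compounds. Its nearest neighbour is compound 2, which gives 3300 nM, a gap beyond the scatter, and the furthest is compound 1, which gives 6400 nM. Among the measured compounds shown here, the only single-step comparison among the measured compounds, a 1.9-fold lower number from compound 1 to compound 2 (0.29 log units; within the scatter), concerns the group on the carbonyl carbon and lies within the scatter.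

Compound 4 `COc1ccc(C(=O)/C=C/c2cn(-c3ccccc3)nc2-c2cccnc2)c(OC)c1` differs from compound 3 by one change: hydrogen in place of methoxy on an aromatic carbon. For the measured compounds named here, no measured pair shows what removing a methoxy group from this aromatic ring does, so the step from compound 1 to compound 2 does not bear on it directly. What the data do show is that compound 3, carrying three methoxy groups, sits well apart from the two compounds without that ring. Taking one methoxy group away is expected to cost only part of that separation, if any, and the estimate is a 1.8-fold higher number from compound 3 to compound 4 (0.26 log units; within the scatter) in this assay. Compound 4 is therefore expected to give about 900 nM, within a range of 300 nM to 2700 nM.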

Compound 4, half-maximal inhibitory concentration: 2400 nM
Estimate against measurement, compound 4: 2.7-fold (0.43 log units) below, within the range that was stated.
By their numbers in this assay, from the lowest: compound 3; then compounds 4, 2 and 1 (each within the scatter of the next, the first and the last beyond it).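

Among the compounds shown here, replacing one methoxy group of compound 3 with hydrogen, on the aromatic carbon ortho to a large group and meta to two methoxy groups, gives a 4.8-fold higher number from compound 3 to compound 4 (0.68 log units; beyond the scatter) in this assay, so this single position carries a measurable share of the standing of compound 3, which the earlier compounds, none of them one change away from it, could not show. For the compounds shown here, the remaining 2,4-dimethoxyphenyl group does not by itself preserve that standing: it gives a 1.4-fold lower number from compound 2 to compound 4 (0.14 log units; within the scatter) when it replaces 1H-pyrrol-3-yl on the carbonyl carbon, yet a 2.7-fold lower number from compound 1 to compound 4 (0.43 log units; beyond the scatter) when it replaces pyridin-2-yl, so it separates from only one of the two groups. No measurement offered here explains the loss on removing the methoxy group.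

Whether the methoxy group itself is required on this carbon stays open, since the compounds shown place only methoxy and hydrogen there, and an ethoxy group, a hydroxy group or a fluorine atom could tell the two readings apart. What each of the other two methoxy groups contributes on its own also remains unresolved.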